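The source may hold more compounds than are shown below. What is called first, only, known or untested is meant among the compounds shown, and "the series" means these compounds.

Compound 1 `NC(=O)[C@@H]1[C@H](Nc2nc(Nc3cccc(C(=O)N4CCCC4)c3)ncc2-c2cccnc2)[C@H]2C=C[C@@H]1C2` gives 320 nM
Compound 2 `NC(=O)[C@@H]1[C@H](Nc2nc(Nc3cccc(C(=O)N4CCCC4)c3)ncc2-c2ccncc2)[C@H]2C=C[C@@H]1C2` gives 320 nM

Measured in a functional assay on THP-1 cells (Homo sapiens) for inhibition, read by ELISA, with stated times of 1 h and 18 h (a lower number here means a stronger inhibitor, a higher number a weaker inhibitor), compound 2 reads 320 nM and stands level with compound 1 at 320 nM. The next compound to consider is compound 3 `NC(=O)[C@@H]1[C@H](Nc2nc(Nc3cccc(C(=O)N4CCCC4)c3)ncc2-c2ccc(F)cc2)[C@H]2C=C[C@@H]1C2`, which keeps the rest of compound 2 and alters one group on an aromatic carbon: 4-fluorophenyl in place of pyridin-4-yl on an aromatic carbon. Here 4-fluorophenyl takes the place of pyridin-4-yl, so a ring holding a nitrogen gives way to a ring of carbon only, and a fluorine comes in.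

For the measured compounds named here, only one measured step bears on this change: no change at the digits printed from compound 1 to compound 2 (within the scatter), where pyridin-4-yl replaced pyridin-3-yl on the same aromatic carbon. That is a swap of one pyridine for another. Going by the values given here, no measured compound carries a ring of carbon only at this place, so the evidence is indirect and the uncertainty is wide. With that caution, no shift beyond the scatter is expected in this assay, in either direction. The expected size is a 1.1-fold lower number from compound 2 to compound 3 (0.03 log units; within the scatter). For compound 3 the estimated value is 300 nM, with an expected range from 100 nM to 900 nM.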

Compound 3, half-maximal inhibitory concentration: 460 nM
Estimate against measurement, compound 3: 1.5-fold (0.19 log units) below, and the stated range covers the measured number.
By their numbers in this assay, from the lowest: compounds 1, 2 and 3 (each within the scatter of the next).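

In this assay, for the compounds shown here, this is the first reading of a ring of carbon only at this aromatic carbon, and it gives a 1.4-fold higher number from compound 2 to compound 3 (0.16 log units; within the scatter) and likewise a 1.4-fold higher number from compound 1 to compound 3 (0.16 log units; within the scatter). Up to now, only pyridine rings had been compared here, so the earlier pair could show only that moving the ring nitrogen made no difference at the digits printed. Among these three compounds, 4-fluorophenyl gives a reading within the scatter of both pyridines, so a ring nitrogen at this place does not appear to be required for activity in this range, and no measurement is at hand to explain the result.

The step from compound 2 to compound 3 removes the ring nitrogen and adds a fluorine at the same time, so a plain phenyl ring would be needed to separate the two changes. All three groups are also six-membered aromatic rings, which leaves open how this position responds to something quite different, such as a methyl group, an amine or a carboxylic acid.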